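Trifluoromethoxy in Place of Fluoro: Tolerance in Liver Cells

The source may hold more compounds than are shown below. What is called first, only, known or untested is meant among the compounds shown, and "the series" means these compounds.

Compound 1 `Cn1c([N+](=O)[O-])cnc1C(=O)NCc1ccc(F)cc1` gives > 100000 nM in this assay.
Compound 2 `COc1ccc(CNC(=O)c2ncc([N+](=O)[O-])n2C)cc1` gives > 100000 nM in this assay.
Compound 3 `O=C(NCc1ccc(F)cc1)c1ncc([N+](=O)[O-])[nH]1` gives > 100000 nM in this assay.

For the measured compounds named here, in a toxicity assay on HepG2 cells (Homo sapiens) for inhibition, read by resazurin assay, with a stated time of 24 h (a higher number here means that more compound is tolerated, a lower number that less compound is tolerated), every value so far is a limit of the assay rather than a number. Compound 3 sits at > 100000 nM, which is such a limit. The two measured steps, a step that the two limits leave unreadable from compound 1 to compound 2 and a step that the two limits leave unreadable from compound 1 to compound 3, cannot be read in size because of the limit of > 100000 nM in this assay, at which 3 of the 3 values shown sit. Compound 4 `O=C(NCc1ccc(OC(F)(F)F)cc1)c1ncc([N+](=O)[O-])[nH]1` differs from compound 3 in one place: trifluoromethoxy in place of fluoro on an aromatic carbon. Going by the values given here, no measured step touches a trifluoromethoxy group, so nothing among the measured compounds points to a change in either direction; the only evidence is that three compounds sharing the core all reached the limit. The step that this estimate means, a number no higher from compound 3 to compound 4 (the limit leaves the size open), is therefore expected to stay within the scatter. Compound 4 is expected to give about 100000 nM, most likely again as a limit, within a range from 40000 nM to 250000 nM.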

Compound 4, half-maximal cytotoxic concentration: 93000 nM
Compound 4: the middle estimate sits 1.1-fold (0.03 log units) above what was measured; measured number inside the range.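

In this assay, for the compounds shown here, compound 4 gives 93000 nM, the only one of the four values shown that is a number and not a limit, so this aromatic carbon, para to a large group, now carries a group with a readable result. Trifluoromethoxy in place of fluoro adds heavy atoms and a hydrogen-bond acceptor, yet the result is an at least 1.0-fold lower number from compound 3 to compound 4 (0.03 log units; that floor lies within the scatter), so no loss of tolerance beyond the scatter can be claimed. As far as these compounds go, the full size of this step stays open because the value it starts from is only a limit: the limit of > 100000 nM in this assay, at which 3 of the 4 values shown sit.

The compounds shown leave open whether an amine or a carboxylic acid on this aromatic carbon would lower the number beyond the scatter. They also leave open whether a longer chain in place of methyl on the aromatic nitrogen of compound 1 would give a number at all.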